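Amine-side substituent variation on the shared benzimidazole-free core

A few compounds are considered here, and "the series" means these few. Any claim that something is new, unique, unknown or untested is made for them only; others in the source may bear on it.

Values in an assay on cells for inhibition of interleukin-5 receptor subunit alpha (Mus musculus), read by WST assay, with a stated time of 48 h, tested at 30 uM, in the presence of a further agent that is not named here; a lower number here means less inhibition, a higher number more inhibition at the concentration tested (going by the name of the read-out):
compound 1 `OCCNCc1nc2c(OCC3CCCCC3)cccc2[nH]1`: 63.3%
compound 2 `CCC(CO)NCc1nc2c(OCC3CCCCC3)cccc2[nH]1`: 94.3%
compound 3 `OCC(NCc1nc2c(OCC3CCCCC3)cccc2[nH]1)c1ccccc1`: 77.7%

Compound 3 stands second highest of the three: a number 14.4 percentage points higher from compound 1 to compound 3 (beyond the scatter), while a number 16.6 percentage points lower from compound 2 to compound 3 (beyond the scatter). Compound 4 `OCC(CC1CCCCC1)NCc1nc2c(OCC3CCCCC3)cccc2[nH]1` is not yet measured; it differs from compound 3 by cyclohexylmethyl in place of phenyl on a saturated chain carbon bound to an amine nitrogen and a saturated chain carbon. The two steps that bear on this are those into compound 3: the modest gain a number 14.4 percentage points higher from compound 1 to compound 3 (beyond the scatter) and the modest loss a number 16.6 percentage points lower from compound 2 to compound 3 (beyond the scatter), the latter showing that the saturated ethyl group gave the highest number of the set. A saturated cyclohexylmethyl entering in place of phenyl is therefore expected to raise the read-out modestly, toward the level of compound 2, by about a number 8.3 percentage points higher from compound 3 to compound 4 (within the scatter). For compound 4 the estimate is 86%, within 70% to 97%.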

Compound 4, a percentage reported as inhibition, at one concentration (the size of the read-out at that concentration, not a potency): 94.7%
Compound 4: middle estimate off by 8.7 percentage points, on the low side; the range from low to high includes it.
By their numbers in this assay, from the lowest: compound 1; then compound 3; then compounds 2 and 4 (each within the scatter of the next).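

In this assay cyclohexylmethyl in place of phenyl gives a number 17 percentage points higher from compound 3 to compound 4 (beyond the scatter) and so shows that a ring at this carbon need not cost inhibition when it is saturated. Against hydrogen the same group gives a number 31.4 percentage points higher from compound 1 to compound 4 (beyond the scatter) as its step. Cyclohexyl in place of methyl gives a number 0.4 percentage points higher from compound 2 to compound 4 (within the scatter) and so leaves compound 2 and compound 4 not separated at this single concentration.

On these data alone, what a carboxylic acid or an amine on this chain would do remains open. No evidence at hand explains the difference between the saturated and aromatic groups.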